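Swapping the aryl group on the shared core of compound 1

This account rests on a few compounds, and the source may have more. Where it says the series, first, only, none or still open, it means among the compounds named here.

Measured compounds:
- compound 1 `COc1cccc(-c2c(C)nn(-c3nc(-c4ccc(Cl)c(Cl)c4)c(SC(C)C)s3)c2C(=O)O)c1`: 14000 nM
- compound 2 `COc1cncc(-c2c(C)nn(-c3nc(-c4ccc(Cl)c(Cl)c4)c(SC(C)C)s3)c2C(=O)O)c1`: 21000 nM
- compound 3 `Cc1ccccc1-c1c(C)nn(-c2nc(-c3ccc(Cl)c(Cl)c3)c(SC(C)C)s2)c1C(=O)O`: 5500 nM

In a functional assay on BJAB cells (Homo sapiens) for antiproliferative activity, with a stated time of 4 days (on this read-out lower numbers stand for an effect already at smaller amounts and higher numbers for an effect only at larger amounts of compound), compound 1 gives 14000 nM, the second highest of the three numbers. The 5-methoxypyridin-3-yl of compound 2 changes little, as the step of a 1.5-fold higher number from compound 1 to compound 2 (0.18 log units; within the scatter) shows. The 2-methylphenyl of compound 3 does more: a 2.5-fold lower number from compound 1 to compound 3 (0.41 log units; beyond the scatter), and likewise a 3.8-fold lower number from compound 2 to compound 3 (0.58 log units; beyond the scatter).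

Compound 4 `CC(=O)Nc1ccc(-c2c(C)nn(-c3nc(-c4ccc(Cl)c(Cl)c4)c(SC(C)C)s3)c2C(=O)O)cc1` is not yet measured. It differs from compound 1 in one place: 4-acetamidophenyl in place of 3-methoxyphenyl on an aromatic carbon. Within the data shown here, no measured step exchanges the aryl group for one that carries both a hydrogen-bond donor and an acceptor, so the closest guide is the pair of steps from compound 1, one within the scatter and one modest. The expected step is therefore small, a 1.1-fold higher number from compound 1 to compound 4 (0.03 log units; within the scatter), with no direction favoured. Compound 4 is estimated at 15000 nM in this assay, with a range from 6000 nM to 40000 nM.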

Compound 4, half-maximal effective concentration: 139000 nM
Beside the measured number, compound 4's estimate is 9.3-fold (0.97 log units) below it; the measured number lies above the stated range.
By their numbers in this assay, from the lowest: compound 3; then compounds 1 and 2 (each within the scatter of the next); then compound 4.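

The aryl position on the shared core tolerates less than the first three compounds suggested. In this assay, among these compounds, the 4-acetamidophenyl group gives a 9.9-fold higher number from compound 1 to compound 4 (1.00 log units; beyond the scatter) and a 6.6-fold higher number from compound 2 to compound 4 (0.82 log units; beyond the scatter) and also a 25-fold higher number from compound 3 to compound 4 (1.40 log units; beyond the scatter) as the widest gap in the set, so the choice of aryl group can shift this read-out much further than the earlier steps showed. Compared with the 3-methoxyphenyl of compound 1, the new group is larger and carries a hydrogen-bond donor, but nothing available shows which of these differences, if either, accounts for the higher number.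

Going by these compounds, it remains open whether a 4-aminophenyl group, with a free amine in place of the acetamide, would give a number closer to that of compound 1 or compound 4. The same question applies to a 4-methoxyphenyl group, which would keep the methoxy group of compound 1 but place it as the acetamide sits in compound 4.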